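Swapping Propyl for Vinyl on a Long Chain

The source may hold more compounds than are shown below. What is called first, only, known or untested is meant among the compounds shown, and "the series" means these compounds.

Compound 1 `CCCCCCCC(=O)Nc1nnc(S[C@@H]2O[C@H](CO)[C@H](O)[C@H](O)[C@H]2O)s1`: 50800 nM
Compound 2 `CCCCCCCCCCCC(=O)Nc1nnc(S[C@@H]2O[C@H](CO)[C@H](O)[C@H](O)[C@H]2O)s1`: 8700 nM

In a functional assay on HeLa cells (Homo sapiens) for cytotoxicity, read by MTT assay, with a stated time of 24 h (on this read-out higher numbers stand for weaker inhibition and lower numbers for stronger inhibition), compound 2 has the lower of the two numbers, so it shows the stronger inhibition. Compound 3 `C=CCCCCCCCCC(=O)Nc1nnc(S[C@@H]2O[C@H](CO)[C@H](O)[C@H](O)[C@H]2O)s1` differs from compound 2 in one place: vinyl in place of propyl on a saturated chain carbon, eight bonds along the chain from a carbonyl carbon. Among the compounds with values here, only one measured step bears on this change, a modest one with butyl in place of hydrogen on the chain: a 5.8-fold lower number from compound 1 to compound 2 (0.77 log units; beyond the scatter). The present swap alters the chain far less, so a smaller step is expected in this assay: a 1.5-fold higher number from compound 2 to compound 3 (0.17 log units; within the scatter). For compound 3 the estimated value is 13000 nM, with an expected range of 6000 nM to 28000 nM.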

Compound 3, half-maximal inhibitory concentration: 58300 nM
Estimate against measurement, compound 3: 4.5-fold (0.65 log units) below; the measured number lies above the stated range.
By their numbers in this assay, from the lowest: compound 2; then compounds 1 and 3 (each within the scatter of the next).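

In this assay, the swap of propyl for vinyl at this chain position is not a minor edit: a 6.7-fold higher number from compound 2 to compound 3 (0.83 log units; beyond the scatter). The comparison with the shorter chain shows how much this matters, with a 1.1-fold higher number from compound 1 to compound 3 (0.06 log units; within the scatter), so compound 3 does not keep the stronger inhibition seen in compound 2. Among these three compounds, then, the end of the chain counts as well as the chain's growth.

Nothing available explains why the vinyl end behaves this way. As far as these compounds go, whether a longer chain, or an amine or carboxylic acid at the chain end, would restore the stronger inhibition remains open.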